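Trifluorobenzyl in place of butyl on the shared core

The source may hold more compounds than are shown below. What is called first, only, known or untested is meant among the compounds shown, and "the series" means these compounds.

Measured in an assay on CHO cells for activation of soluble guanylate cyclase alpha1/beta1 complex (Homo sapiens), read by cGMP accumulation (a higher number here means that more compound is needed for the effect, a lower number that less compound is needed), so far:
compound 1 `COC(=O)N(C)c1c(N)nc(-n2nc(Cc3ccccc3F)c3cc(F)ccc32)nc1N` gives 960 nM
compound 2 `CCCc1nn(-c2nc(N)c3c(n2)NC(=O)C3(C)C)c2ccc(Cl)cc12` gives 546000 nM
compound 3 `CCCCc1nn(-c2nc(N)c3c(n2)NC(=O)C3(C)C)c2ccc(Cl)cc12` gives 47000 nM

Compound 3 stands second highest of the three numbers in this assay: compound 2 sits above it and compound 1 far below it. Among the measured compounds shown here, the one step measured, a 12-fold lower number from compound 2 to compound 3 (1.07 log units; beyond the scatter), came from lengthening the chain by a single carbon.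

Compound 4 `CC1(C)C(=O)Nc2nc(-n3nc(Cc4c(F)ccc(F)c4F)c4cc(Cl)ccc43)nc(N)c21` carries the change (2,3,6-trifluorophenyl in place of propyl on a saturated chain carbon bound to an aromatic carbon). For the measured compounds named here, no measured pair shows this exchange on the shared core, so no step bears on it directly. Compound 1, which carries a fluorinated benzyl group on a different core, gives 960 nM, the lowest number shown, and the step from compound 2 to compound 3 shows that this position responds strongly to what is placed there. On that basis compound 4 is expected to give a lower number than compound 3 in this assay, by a step of a 16-fold lower number from compound 3 to compound 4 (1.19 log units; beyond the scatter). The estimate for compound 4 is 3000 nM, within a range of 400 nM to 20000 nM.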

Compound 4, half-maximal effective concentration: 7300 nM
Compound 4: the middle estimate sits 2.4-fold (0.39 log units) below what was measured, within the range that was stated.
By their numbers in this assay, from the lowest: compound 1; then compound 4; then compound 3; then compound 2.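

In this assay, the saturated chain carbon bound to an aromatic carbon accepts an aromatic ring as well as an alkyl chain: exchanging butyl for 2,3,6-trifluorobenzyl on the shared core gives a 6.4-fold lower number from compound 3 to compound 4 (0.81 log units; beyond the scatter). Measured against the shorter chain of compound 2, the exchange gives a 75-fold lower number from compound 2 to compound 4 (1.87 log units; beyond the scatter), so both the added chain carbon and the trifluorobenzyl group lower the number on this core. Nothing available explains why this ring lowers the number relative to the butyl chain.

From the compounds shown here alone, whether the three fluorine atoms contribute anything remains open, since a plain benzyl group could give a similar number, and a pentyl chain might match or pass the trifluorobenzyl group. Compound 1 differs from compound 4 in more than one place, so it cannot settle how much of its lower number belongs to its core.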